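From compound 3 to compound 4: an untested swap

The source may hold more compounds than are shown below. What is called first, only, known or untested is meant among the compounds shown, and "the series" means these compounds.

In an ADME assay on BaF3 cells (Mus musculus) for antiproliferative activity (on this read-out higher numbers stand for weaker inhibition of growth and lower numbers for stronger inhibition of growth), compound 1 `Cc1ccc(NC(=O)c2ccc(C)c(C(F)(F)F)c2)cc1OC1CCN(C(=O)c2ccncc2)CC1` gives 6390 nM, compound 2 `Cc1ccc(NC(=O)c2ccc(C)c(C(F)(F)F)c2)cc1OC1CCN(C(=O)c2cccnc2)CC1` gives 5470 nM and compound 3 `Cc1ccc(NC(=O)c2ccc(C)c(C(F)(F)F)c2)cc1OC1CCN(C(=O)c2ccno2)CC1` gives 8940 nM. These three numbers lie within the usual scatter of one another, so compound 3 stands level with the other two.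

Compound 4 `Cc1ccc(NC(=O)c2cc(Cl)cc(C(F)(F)F)c2)cc1OC1CCN(C(=O)c2ccno2)CC1` differs from compound 3 in one place: 3-chloro-5-(trifluoromethyl)phenyl in place of 4-methyl-3-(trifluoromethyl)phenyl on a carbonyl carbon. In words, 3-chloro-5-(trifluoromethyl)phenyl comes in place of 4-methyl-3-(trifluoromethyl)phenyl on a carbonyl carbon whose other neighbour is an amide-type nitrogen.

The measured steps are a 1.2-fold lower number from compound 1 to compound 2 (0.07 log units; within the scatter), a 1.4-fold higher number from compound 1 to compound 3 (0.15 log units; within the scatter) and a 1.6-fold higher number from compound 2 to compound 3 (0.21 log units; within the scatter). All three lie within the scatter, and all three exchange a different group, on a different carbonyl carbon. None of them tests this change, so they bear on it only indirectly, and the data give no direction for it.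

In this assay the expected result is a 1.1-fold lower number from compound 3 to compound 4 (0.05 log units; within the scatter), which means no expected step beyond the scatter. For compound 4 the estimated value is 8000 nM, with an expected range from 2500 nM to 20000 nM.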

Compound 4, concentration for 50% growth inhibition: > 10000 nM
Compound 4: no number, only a limit; the forecaster's own chance of this, stated with the estimate: 15%; middle value at least 1.2-fold (0.09 log units) away from the limit.
By their numbers in this assay, from the lowest: compounds 2, 1 and 3 (each within the scatter of the next). At a limit, above all of these: compound 4.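

Compound 4 gives no number in this assay, only a limit of the assay: the limit of > 10000 nM in this assay, at which 1 of the 4 values shown sits.

From the compounds shown here alone, the step reads an at least 1.1-fold higher number from compound 3 to compound 4 (0.04 log units; that floor lies within the scatter), so the true size of this change stays unknown: it may be small or much larger. Still, this is the first change shown on the carbonyl carbon that carries the phenyl group, and it shows that 3-chloro-5-(trifluoromethyl)phenyl brings no lower number there, at least alongside the 1,2-oxazol-5-yl group of compound 3.

Open, going by these compounds, is whether this swap would behave the same alongside the pyridin-3-yl group of compound 2 or the pyridin-4-yl group of compound 1. Also open, on these data alone, is whether a phenyl group with an amine or a carboxylic acid in place of the chlorine would give a lower number at this place.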